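The compounds below may be only part of what the source reports. "The series", "measured", "known", "first", "only" and "open" are said of these compounds alone.

Compound 1 `O=C1C(NC2CCCC2)=CC(=O)c2c1nc1n2[C@H]2OC[C@@H](O)[C@H]2OC1` carries a cyclopentyl on the amine nitrogen. In a functional assay on HeLa cells (Homo sapiens) for inhibition, read by sulforhodamine B assay (a lower number here means a stronger inhibitor, a higher number a weaker inhibitor), compound 1 gives only a limit, > 16000 nM. Compound 2 `O=C1C(Nc2ccc(I)cc2)=CC(=O)c2c1nc1n2[C@H]2OC[C@@H](O)[C@H]2OC1` has 4-iodophenyl in place of cyclopentyl on an amine nitrogen, and in this assay compound 2 gives 4010 nM. The step is an at least 3.9-fold lower number from compound 1 to compound 2 (0.60 log units; beyond the scatter), read against (the limit of > 16000 nM in this assay, at which 1 of the 2 values shown sits). Among the measured compounds shown here, compound 2 thus holds the only number in this assay so far; the other value is a limit. Compound 3 `O=C1C(N2CCC2)=CC(=O)c2c1nc1n2[C@H]2OC[C@@H](O)[C@H]2OC1` follows with azetidin-1-yl in place of (4-iodophenyl)amino on a double-bonded ring carbon. For the measured compounds named here, the only measured step, an at least 3.9-fold lower number from compound 1 to compound 2 (0.60 log units; beyond the scatter), went from a non-aromatic ring on the amine nitrogen to an aromatic one. Compound 3 returns to a non-aromatic ring, now without the amine hydrogen, so for compound 3 a step back towards a weaker number is expected in this assay, estimated as a 3.0-fold higher number from compound 2 to compound 3 (0.48 log units; beyond the scatter). For compound 3 the expected value is 12000 nM, range 4000 nM to 40000 nM, with a real chance of a limit only.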

Compound 3, half-maximal inhibitory concentration: > 16000 nM
Compound 3: only a limit was reported; the forecaster's own chance of this, stated with the estimate: 40%; middle value at least 1.3-fold (0.12 log units) away from the limit.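

In this assay, azetidin-1-yl in place of (4-iodophenyl)amino on the double-bonded ring carbon gives an at least 3.9-fold higher number from compound 2 to compound 3 (0.60 log units; beyond the scatter). Compound 3 gives only a limit, and the step between compound 1 and compound 3 cannot be read. Of the three compounds, only compound 2, with its aromatic ring on the amine nitrogen, gives a number, while the non-aromatic rings reach the limit both with the amine hydrogen in compound 1 and without it in compound 3: the limit of > 16000 nM in this assay, at which 2 of the 3 values shown sit.

As far as these compounds go, compound 2 alone cannot separate any contribution of the iodine from that of the aromatic ring, so phenylamino and 4-chlorophenylamino remain open comparisons. From the compounds shown here alone, how far a benzylamino or dimethylamino group at this place would move the number also stays open.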